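Benzyl swaps on the shared core

A few compounds are considered here, and "the series" means these few. Any claim that something is new, unique, unknown or untested is made for them only; others in the source may bear on it.

Measured compounds:
compound 1 `Nc1nc(N)c(-c2ccc(NCc3csc(Cl)c3)cc2)c(COCc2ccccc2)n1` gives 170 nM in a functional assay on CHOK cells for antagonist activity at growth hormone secretagogue receptor type 1 (Homo sapiens), read by calcium flux; a higher number here means a weaker inhibitor, a lower number a stronger inhibitor.
compound 2 `COc1ccc(CNc2ccc(-c3c(N)nc(N)nc3COCc3ccccc3)cc2)cc1` gives 90 nM in this assay.
compound 3 `Nc1nc(N)c(-c2ccc(NCc3cnc4ccccc4c3)cc2)c(COCc2ccccc2)n1` gives 780 nM in this assay.

Compound 2 holds the lowest number of the three; compound 1 sits nearest, with a 1.9-fold lower number from compound 1 to compound 2 (0.28 log units; within the scatter), and compound 3 furthest, with an 8.7-fold higher number from compound 2 to compound 3 (0.94 log units; beyond the scatter). Compound 4 `N#Cc1ccc(COc2ccc(-c3c(N)nc(N)nc3COCc3ccccc3)cc2)cc1` differs from compound 2 by (4-cyanobenzyl)oxy in place of (4-methoxybenzyl)amino on an aromatic carbon. Within the data shown here, the measured steps, a 4.6-fold higher number from compound 1 to compound 3 (0.66 log units; beyond the scatter) among them, all swap the group on the saturated chain carbon while the nitrogen on the aromatic ring stays; no step exchanges that nitrogen for an oxygen or brings in a nitrile, so they bear on this change only loosely. Their size, modest at most, suggests a modest step in this assay, direction open. Compound 4 is therefore expected at 180 nM, range 45 nM to 700 nM, which means an expected step of a 2.0-fold higher number from compound 2 to compound 4 (0.30 log units; within the scatter).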

Compound 4, half-maximal inhibitory concentration: 3610 nM
Compound 4: middle estimate off by 20-fold (1.30 log units), on the low side; measured number above the stated range.
By their numbers in this assay, from the lowest: compounds 2 and 1 (each within the scatter of the next); then compound 3; then compound 4.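

In this assay the exchange of (4-methoxybenzyl)amino for (4-cyanobenzyl)oxy on this aromatic carbon gives a 40-fold higher number from compound 2 to compound 4 (1.60 log units; beyond the scatter) against an 8.7-fold higher number from compound 2 to compound 3 (0.94 log units; beyond the scatter) for the largest step with the nitrogen kept. The step of a 21-fold higher number from compound 1 to compound 4 (1.33 log units; beyond the scatter) is also large, so the rise does not depend on one amino partner. The entering group counts no hydrogen-bond donor where the leaving group counts one, and nothing measured here explains the size of the step. Oxygen and nitrile enter together, so their shares stay unresolved; (4-cyanobenzyl)amino and (4-methoxybenzyl)oxy would separate them.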